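Series notes: oxygen substituent on the pendant ring

A few compounds are considered here, and "the series" means these few. Any claim that something is new, unique, unknown or untested is made for them only; others in the source may bear on it.

Three compounds of this series have numbers in a functional assay on Jurkat cells (Homo sapiens) for antiproliferative activity, read by MTT assay; a lower number here means a stronger inhibitor, a higher number a weaker inhibitor. Compound 1 `COc1cc2c(cc1OC)C(=O)/C(=C/c1cc(C)c([N+](=O)[O-])c(C)c1)C2` gives 25000 nM. Compound 2 `COc1cc2c(cc1OC)C(=O)/C(=C/c1cc(C)c(N)c(C)c1)C2` gives 55 nM. Compound 3 `COc1cc2c(cc1OC)C(=O)/C(=C/c1cc(C)c(OC(C)=O)c(C)c1)C2` gives 400 nM, the second highest of the three; it sits a 7.3-fold higher number from compound 2 to compound 3 (0.86 log units; beyond the scatter) and a 63-fold lower number from compound 1 to compound 3 (1.80 log units; beyond the scatter). The other step on record is a 450-fold lower number from compound 1 to compound 2 (2.66 log units; beyond the scatter).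

Compound 4 `CCOC(=O)COc1c(C)cc(/C=C2\Cc3cc(OC)c(OC)cc3C2=O)cc1C` differs from compound 3 by (ethoxycarbonyl)methyl in place of acetyl on an oxygen on an aromatic ring. Among the compounds with values here, no measured step changes what hangs on that oxygen: every step so far swaps the whole group on the aromatic carbon, so the measured steps bear on this change only loosely. An ester chain in place of the acetyl keeps an oxygen on the ring, as in compound 3, so a step of modest size at most is expected, in either direction, most likely within the scatter. Compound 4 is therefore expected to give about 600 nM, between 150 nM and 2500 nM, which would mean a 1.5-fold higher number from compound 3 to compound 4 (0.18 log units; within the scatter).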

Compound 4, half-maximal inhibitory concentration: 2200 nM
Beside the measured number, compound 4's estimate is 3.7-fold (0.56 log units) below it, and the stated range covers the measured number.
By their numbers in this assay, from the lowest: compound 2; then compound 3; then compound 4; then compound 1.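

In this assay, what hangs on the ring oxygen matters and not only the oxygen itself: acetoxy to (ethoxycarbonyl)methoxy is not a neutral exchange (a 5.5-fold higher number from compound 3 to compound 4 (0.74 log units; beyond the scatter)). Compound 4 remains much weaker than the amino compound (a 40-fold higher number from compound 2 to compound 4 (1.60 log units; beyond the scatter)) but clearly stronger than the nitro compound (an 11-fold lower number from compound 1 to compound 4 (1.06 log units; beyond the scatter)), so among these compounds, an oxygen on the aromatic carbon does not set the number by itself, and the order is now amino, acetoxy, (ethoxycarbonyl)methoxy, nitro. Nothing available explains the loss on going from acetyl to (ethoxycarbonyl)methyl.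

The compounds shown do not separate the effect of the longer chain from that of its ethyl ester. A free hydroxyl, a methoxy or the carboxylic acid of this chain on the same oxygen would help to tell these apart.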